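An Arylmethyl Ester in Place of the Free Acid

A few compounds are considered here, and "the series" means these few. Any claim that something is new, unique, unknown or untested is made for them only; others in the source may bear on it.

Compound 3 `C/C=C1/[C@H](O[C@@H]2O[C@H](CO)[C@@H](O)[C@H](O)[C@H]2O)OC=C(C(=O)OC)[C@H]1CC(=O)O` carries a free carboxylic acid on its side chain. In a functional assay on SK-BR-3 cells (Homo sapiens) for antiproliferative activity, read by MTT assay, with a stated time of 72 h (on this read-out lower numbers stand for stronger inhibition and higher numbers for weaker inhibition), compound 3 returns only the limit of the assay, > 15000 nM. Two esters of the same core give the points of comparison. Compound 1 `C/C=C1/[C@H](O[C@@H]2O[C@H](CO)[C@@H](O)[C@H](O)[C@H]2O)OC=C(C(=O)OC)[C@H]1CC(=O)OCCC1CCCCC1` is the 2-cyclohexylethyl ester, and in this assay compound 1 gives 2000 nM. Compound 2 `C/C=C1/[C@H](O[C@@H]2O[C@H](CO)[C@@H](O)[C@H](O)[C@H]2O)OC=C(C(=O)OC)[C@H]1CC(=O)OCc1ccccc1` is the benzyl ester. In this assay compound 2 also sits at the limit, > 15000 nM. Removing the 2-cyclohexylethyl group produces an at least 7.5-fold higher number from compound 1 to compound 3 (0.87 log units; beyond the scatter), so an ester can clearly lower the number; swapping cyclohexylmethyl for phenyl produces an at least 7.5-fold higher number from compound 1 to compound 2 (0.87 log units; beyond the scatter), so not every ester does. The step that the two limits leave unreadable from compound 2 to compound 3, because of the limit of > 15000 nM in this assay, at which 2 of the 3 values shown sit, cannot be sized.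

Compound 4 `C/C=C1/[C@H](O[C@@H]2O[C@H](CO)[C@@H](O)[C@H](O)[C@H]2O)OC=C(C(=O)OC)[C@H]1CC(=O)OCc1ccc2c(c1)OCCO2` differs from compound 3 in one place: (2,3-dihydro-1,4-benzodioxin-6-yl)methyl in place of hydrogen on an oxygen next to a carbonyl group. The nearest measured analogue is compound 2, whose benzyl ester stayed at the limit, while compound 1 shows what a more saturated ester can achieve. The step from the acid is therefore expected to be an at least 1.2-fold lower number from compound 3 to compound 4 (0.09 log units; that floor lies within the scatter), with a real chance that the assay again reports only a limit. Compound 4 is estimated at 12000 nM, within a range of 4000 nM to 30000 nM.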

Compound 4, half-maximal inhibitory concentration: > 15000 nM
Compound 4: a limit, no number; the forecaster's own chance of this, stated with the estimate: 50%; at least 1.2-fold (0.09 log units) between middle value and limit.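

With the (2,3-dihydro-1,4-benzodioxin-6-yl)methyl group on the oxygen next to the carbonyl, a second arylmethyl ester now stays at the end of the range, so the outcome for compound 2 is no longer a single case. In this assay compound 4 gives > 15000 nM, which is a limit of the assay and not a number. Compound 1 remains the only ester here with a measured value, and the one readable step is an at least 7.5-fold higher number from compound 1 to compound 4 (0.87 log units; beyond the scatter), while the steps from compound 3 and from compound 2 to compound 4 cannot be read, as each joins two limits: the limit of > 15000 nM in this assay, at which 3 of the 4 values shown sit.

The compounds shown leave open whether the measured value of compound 1 goes with its saturated ring or with its longer chain, and a 2-phenylethyl ester or a cyclohexylmethyl ester on the shared core would separate the two. From the compounds shown here alone, how far compound 2, compound 3 and compound 4 differ from one another also stays open, as none of them has a value inside the range of the assay.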